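The source may report more compounds than this note shows. Statements on the series, on what has been measured and on what is new or still open speak of the compounds shown alone.

In a functional assay on K562 cells (Homo sapiens) for antiproliferative activity, read by MTT assay, with a stated time of 5 days (on this read-out higher numbers stand for weaker inhibition and lower numbers for stronger inhibition), compound 1 `COc1ccc(C=C(C(=O)c2cc(OC)c(OC)c(OC)c2)c2ccccc2)cc1[N+](=O)[O-]` gives only a limit, > 10000000 nM. For the measured compounds named here, compound 2 `COc1ccc(C=C(C(=O)c2cc(OC)c(OC)c(OC)c2)c2ccccc2)cc1F`, at 790000 nM, holds the only actual number so far. Compound 3 `COc1cc(C(=O)C(=Cc2ccccc2)c2ccccc2)cc(OC)c1OC` differs from compound 2 by phenyl in place of 3-fluoro-4-methoxyphenyl on a double-bonded chain carbon bound to a double-bonded chain carbon. Going by the values given here, one measured step bears on this change: an at least 12-fold lower number from compound 1 to compound 2 (1.10 log units; beyond the scatter), large and beyond the scatter, shows that a single aromatic substituent can move this assay strongly. A moderate rise, towards weaker inhibition, is expected: a 2.5-fold higher number from compound 2 to compound 3 (0.40 log units; beyond the scatter). For compound 3 the estimated value is 2000000 nM, with an expected range of 300000 nM to 10000000 nM.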

Compound 3, half-maximal inhibitory concentration: 6300000 nM
Estimate against measurement, compound 3: 3.2-fold (0.50 log units) below; measured number inside the range.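

Replacing 3-fluoro-4-methoxyphenyl with phenyl on a double-bonded chain carbon bound to a double-bonded chain carbon weakens inhibition in this assay: an 8.0-fold higher number from compound 2 to compound 3 (0.90 log units; beyond the scatter). Thus, the fluoro and methoxy groups together have a measurable part in the activity of compound 2, which the nitro-to-fluoro step alone did not show. Compound 3 cannot be placed firmly against compound 1, as an at least 1.5-fold lower number from compound 1 to compound 3 (0.20 log units; that floor lies within the scatter) has a floor within the scatter and rests on a limit: the limit of > 10000000 nM in this assay, at which 1 of the 3 values shown sits.

The compounds shown leave open whether the fluoro or the methoxy group accounts for the step, since both leave together. Going by these compounds, how an amine on this phenyl would read also remains open.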